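A few compounds are considered here, and "the series" means these few. Any claim that something is new, unique, unknown or untested is made for them only; others in the source may bear on it.

Measured compounds:
compound 1, `O=c1cc(Cn2cc(CNS(=O)(=O)c3ccc(F)cc3)nn2)c2ccc(O)cc2o1` — 76700 nM
compound 2, `CC(C)(C)OC(=O)N1CCN(C(=S)SCc2cn(Cc3cc(=O)oc4cc(O)ccc34)nn2)CC1` — 56900 nM
compound 3, `O=c1cc(Cn2cc(-n3ccc4cc(I)ccc43)nn2)c2ccc(O)cc2o1` — 8570 nM

All three were tested in a functional assay on HepG2 cells (Homo sapiens) for inhibition, read by MTT assay, with a stated time of 72 h; on this read-out higher numbers stand for weaker inhibition and lower numbers for stronger inhibition. Compound 3 stands lowest of the three numbers in this assay. Its nearest neighbour is compound 2, and its furthest is compound 1; both gaps lie beyond the usual scatter of repeated measurements, so compound 3 can be called the most potent of the three on this read-out. For the measured compounds named here, compound 1 and compound 2 differ from compound 3 in more than one place, so no single-point step between measured compounds is available.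

Compound 4, `Cc1ccc2c(Cn3cc(-n4ccc5cc(I)ccc54)nn3)cc(=O)oc2c1`, has not yet been measured in this assay. It differs from compound 3 in one place: methyl in place of hydroxy on an aromatic carbon. Going by the values given here, no measured pair shows what this change does, so the expectation rests on the value of compound 3 alone, 8570 nM. The step from compound 3 to compound 4 is expected to be small, probably not beyond the scatter, with a slight lean toward a higher number: a 1.4-fold higher number from compound 3 to compound 4 (0.15 log units; within the scatter). Compound 4 is therefore estimated to give about 12000 nM in this assay, with a range from 4000 nM to 40000 nM.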

Compound 4, half-maximal inhibitory concentration: 38100 nM
Compound 4: the middle estimate sits 3.2-fold (0.50 log units) below what was measured; measured number inside the range.
By their numbers in this assay, from the lowest: compound 3; then compounds 4, 2 and 1 (each within the scatter of the next).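

In this assay, methyl in place of hydroxy on this aromatic carbon gives a 4.4-fold higher number from compound 3 to compound 4 (0.65 log units; beyond the scatter), a modest step but one that is beyond the usual scatter, so the hydroxy position is not indifferent to this change. The earlier compounds shown here could not show this, as they differed from one another in more than one place and gave no single-place step. The swap leaves the heavy-atom count unchanged and removes the hydrogen-bond donor and acceptor of the hydroxy, but no measurement at hand accounts for the weaker inhibition.

This single step leaves open whether another group on the same aromatic carbon, such as methoxy, an amine or fluorine, would stay close to compound 3 or move as compound 4 does. For the compounds shown here, it also leaves open whether methyl in place of hydroxy would produce a similar step with the different groups carried by compound 1 and compound 2, since the only step at this position comes from the indole-bearing pair.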